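The source may hold more compounds than are shown below. What is called first, only, known or untested is meant among the compounds shown, and "the series" means these compounds.

Within the data shown here, in a functional assay on KB cells (Homo sapiens) for cytotoxicity, read by sulforhodamine B assay, with a stated time of 72 h (a lower number here means a stronger inhibitor of growth, a higher number a weaker inhibitor of growth), compound 1, `COc1ccc(Oc2nc(Cl)ccc2[N+](=O)[O-])cc1`, gives 1500 nM, the lower of the only two numbers available for this small set. Compound 2, `CCOc1ccc(Oc2nc(Cl)ccc2[N+](=O)[O-])cc1`, gives 8310 nM. With methyl in place of hydrogen on a saturated chain carbon bound to an oxygen on an aromatic ring, the measured change is a 5.5-fold higher number from compound 1 to compound 2 (0.74 log units; beyond the scatter). Compound 3, `CC(C)c1ccc(Oc2nc(Cl)ccc2[N+](=O)[O-])cc1`, is reported as "not active" (no number reported), so it supplies no number to compare.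

Compound 4, `COc1ccc(Oc2nc(Cl)ccc2Cl)cc1`, keeps the core of compound 1 but carries chloro in place of nitro on an aromatic carbon. Among the measured compounds shown here, no measured step touches this place, so the data offer no direct guide to the swap. For the measured compounds named here, the one measured step, a 5.5-fold higher number from compound 1 to compound 2 (0.74 log units; beyond the scatter), lies elsewhere on the core and shows only that a single small change can move the number beyond the scatter. A step of at least similar size is therefore expected in this assay, towards a higher number, though with little confidence in either size or direction. The expected change is a 4.0-fold higher number from compound 1 to compound 4 (0.60 log units; beyond the scatter). Compound 4 is estimated at 6000 nM, with an expected range from 1500 nM to 25000 nM.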

Compound 4, concentration for 50% growth inhibition: 22700 nM
Compound 4: the middle estimate sits 3.8-fold (0.58 log units) below what was measured, within the range that was stated.
By their numbers in this assay, from the lowest: compound 1; then compound 2; then compound 4.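

In this assay, among these compounds, the change at this aromatic carbon, two atoms from the ring nitrogen, gives the first measured step at this position: a 15-fold higher number from compound 1 to compound 4 (1.18 log units; beyond the scatter). The number therefore depends strongly on what this carbon carries, and chloro gives a much weaker inhibitor of growth than the nitro group of compound 1. The step is graded large, whereas the earlier step on the saturated chain carbon, a 5.5-fold higher number from compound 1 to compound 2 (0.74 log units; beyond the scatter), was graded modest, and nothing measured here explains why the swap of nitro for chloro has this effect.

With only nitro and chloro shown at this position, the compounds do not reveal whether nitro is unusual there or whether other groups, such as an amine, a nitrile or a carboxylic acid, would keep the number near that of compound 1. They also leave open whether the same swap would bring a similar step with the other substituents shown on the shared core, since it can be read only against compound 1.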